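The compounds below may be only part of what the source reports. "The series", "measured", "known", "first", "only" and "open" are said of these compounds alone.

The compounds measured so far in a functional assay on MCF7 cells (Homo sapiens) for cytotoxicity, read by MTT assay, with a stated time of 48 h; on this read-out lower numbers stand for stronger inhibition and higher numbers for weaker inhibition:

- compound 1 `COc1cc(C(=O)C2Sc3nnc(-c4cc(OC)c(OC)c(OC)c4)n3NC2c2ccco2)cc(OC)c1OC`; in this assay compound 1 reaches only the limit > 100000 nM.
- compound 2 `COc1cc(-c2nnc3n2NC(c2ccco2)C(C(=O)c2ccc(Br)cc2)S3)cc(OC)c1OC`; in this assay compound 2 reaches only the limit > 100000 nM.
- compound 3 `COc1cc(-c2nnc3n2NC(c2ccco2)C(C(=O)c2ccc(Cl)cc2)S3)cc(OC)c1OC`; in this assay compound 3 reaches only the limit > 100000 nM.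

All three share one core and differ only in the group on the carbonyl carbon. Compound 2 therefore stands at a limit, and the two other values shown are limits too, so no order among them can be read from the numbers.

The unmeasured compound 4 `COc1cc(-c2nnc3n2NC(c2ccco2)C(C(=O)c2ccc([N+](=O)[O-])cc2)S3)cc(OC)c1OC` differs from compound 2 in one place: nitro in place of bromo on an aromatic carbon.

Among the measured compounds shown here, the step that sits on the same aromatic carbon is a step that the two limits leave unreadable from compound 2 to compound 3; its size cannot be read, and the same holds for a step that the two limits leave unreadable from compound 1 to compound 2 and a step that the two limits leave unreadable from compound 1 to compound 3, because every value so far sits at the limit of > 100000 nM in this assay, at which 3 of the 3 values shown sit. For the measured compounds named here, no measured step therefore gives a direction or a size for the change to a nitro group.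

Compound 4 is thus expected to sit again at the limit, with an estimate of 150000 nM and a range from 40000 nM to 600000 nM. The expected step that the limit leaves unreadable from compound 2 to compound 4 is accordingly one whose size cannot be read, with the value most likely remaining a limit rather than a number.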

Compound 4, half-maximal inhibitory concentration: > 100000 nM
Compound 4: only a limit was reported; the forecaster's own chance of this, stated with the estimate: 80%; the middle value lies beyond the limit too.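

In this assay compound 4 gives > 100000 nM, which is a limit and not a number. Among the compounds shown here, no step between compound 4 and compound 1, compound 2 or compound 3 can be read, because all the values sit at the same limit: the limit of > 100000 nM in this assay, at which 4 of the 4 values shown sit. The compounds shown leave open whether changing the group on the carbonyl carbon alters cytotoxicity at all.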